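Aryl ketone exchange in an aminothiophene series

This account rests on a few compounds, and the source may have more. Where it says the series, first, only, none or still open, it means among the compounds named here.

Compound 1 `Nc1scc(CN2CCN(c3ccc(F)cc3Cl)CC2)c1C(=O)c1ccc(Cl)cc1`: in a functional assay on CHO cells with adenosine receptor A1 (Homo sapiens) as the target, read by cAMP accumulation and immunoassay, with a stated time of 6 min, tested at 0.01 uM (a higher number here means a weaker effect of the compound at the concentration tested, a lower number a stronger effect), compound 1 gives 6.1%.
Compound 2 `Nc1scc(CN2CCN(c3ccc(Cl)c(C(F)(F)F)c3)CC2)c1C(=O)c1ccc(Cl)cc1`: in this assay compound 2 gives -2.5%.
Compound 3 `Nc1scc(CN2CCN(c3c(F)cccc3F)CC2)c1C(=O)c1cccc(C(F)(F)F)c1`: in this assay compound 3 gives 2.1%.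

Compound 3 stands second highest of the three numbers; compound 1 is nearest, within the scatter, and compound 2 is furthest, also within the scatter. Compound 4 `Nc1scc(CN2CCN(c3c(F)cccc3F)CC2)c1C(=O)c1ccc(Cl)cc1` differs from compound 3 by 4-chlorophenyl in place of 3-(trifluoromethyl)phenyl on a carbonyl carbon. Within the data shown here, the single measured step, a number 8.6 percentage points lower from compound 1 to compound 2 (within the scatter), alters the aryl group on the amine nitrogen in a ring and lies within the scatter; no measured step touches the carbonyl carbon. Nothing here points to a step beyond the scatter in this assay in either direction. Compound 4 is therefore expected to give an estimated 2%, with a range from -10% to 14%. The expected step is a number 0.1 percentage points lower from compound 3 to compound 4 (within the scatter).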

Compound 4, a percentage reported as activity, at one concentration (the size of the read-out at that concentration, not a potency): -12%
Compound 4: middle estimate off by 14 percentage points, on the high side, and the stated range ends above it.
By their numbers in this assay, from the lowest: compounds 4, 2, 3 and 1 (each within the scatter of the next, the first and the last beyond it).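

In this assay, among these compounds, the exchange on a carbonyl carbon, 4-chlorophenyl in place of 3-(trifluoromethyl)phenyl, gives a number 14.1 percentage points lower from compound 3 to compound 4 (beyond the scatter) and is the first reading at this position, a modest stronger effect at the concentration tested. With 4-chlorophenyl held there, the aryl group on the amine nitrogen in a ring gives a number 18.1 percentage points lower from compound 1 to compound 4 (beyond the scatter) and also a number 9.5 percentage points lower from compound 2 to compound 4 (within the scatter). Nothing at hand accounts for the shift at the carbonyl carbon. Among the compounds shown here, the exchange is seen only with 2,6-difluorophenyl on the amine nitrogen, so its size with other aryl groups stays open. Also open, on these data alone, is how a phenyl carrying a carboxylic acid, or a cyclohexyl ring, would read on the carbonyl carbon.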